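Ester to Ketone on a Thiophene Dihydropyrimidinone Series

The compounds below may be only part of what the source reports. "The series", "measured", "known", "first", "only" and "open" are said of these compounds alone.

Measured compounds:
compound 1 `CC1=C(C(=O)OCC(C)C)C(c2cccs2)NC(=O)N1`, in an assay on membranes from CHO cells for displacement of a labelled ligand from adenosine receptor A1 (Homo sapiens), read by scintillation counting, with a stated time of 60 min, tested at 1 uM (on this read-out higher numbers stand for more inhibition at the one concentration tested (going by the name of the read-out) and lower numbers for less inhibition), compound 1 gives 25%
compound 2 `CC1=C(C(=O)OC(C)(C)C)C(c2ccsc2)NC(=S)N1`, compound 2 gives 16%
compound 3 `CC1=C(C(=O)OCC(C)C)C(c2cccs2)NC(=O)N1C`, compound 3 gives 9%

Compound 1 has the highest number of the three. Compound 2 is nearest, and the gap between them is within the scatter, so no order between compound 1 and compound 2 can be read. Compound 3 is furthest: a number 16 percentage points lower from compound 1 to compound 3 (beyond the scatter).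

The unmeasured compound 4 `CC1=C(C(=O)CC(C)C)C(c2cccs2)NC(=O)N1` differs from compound 1 in one place: isobutyl in place of isobutoxy on a carbonyl carbon. Among the measured compounds shown here, the only step measured so far changes a hydrogen on a ring nitrogen for a methyl and does not touch the carbonyl carbon, so no measured step bears directly on this change. For the measured compounds named here, the data give no guide beyond the fact that the one change measured lowered the number. With a hydrogen-bond acceptor leaving and nothing comparable entering, a small drop or no change beyond the scatter is expected. Compound 4 is therefore estimated at 15%, within 2% to 30%. This estimate means an expected step of a number 10 percentage points lower from compound 1 to compound 4 (within the scatter).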

Compound 4, a percentage reported as inhibition, at one concentration (the size of the read-out at that concentration, not a potency): 19%
Beside the measured number, compound 4's estimate is 4 percentage points below it; the measured number falls inside the stated range.
By their numbers in this assay, from the lowest: compounds 3, 2, 4 and 1 (each within the scatter of the next, the first and the last beyond it).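

In this assay, among the compounds shown here, isobutyl in place of isobutoxy on the carbonyl carbon gives a number 6 percentage points lower from compound 1 to compound 4 (within the scatter) and this is the first measured change at this position. Since the step lies within the scatter, the oxygen of the isobutoxy group and the hydrogen-bond acceptor counted with it can go without a readable change in this read-out, whereas the methyl on the ring nitrogen gives a number 16 percentage points lower from compound 1 to compound 3 (beyond the scatter) and that step lies beyond the scatter. No supporting measurement is available to explain this result.

On these data alone, what an amine or a carboxylic acid on this carbonyl carbon would do stays open, as does whether a longer chain there would give a step beyond the scatter. As far as these compounds go, because each number comes from a single concentration, the potency of compound 1 and compound 4 also remains open.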